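Swapping an ester for a thioester on a long diene chain

This account rests on a few compounds, and the source may have more. Where it says the series, first, only, none or still open, it means among the compounds named here.

Measured compounds:
- compound 1, `CCCOC(=O)/C=C(C)/C=C/CC(C)CCCC(C)C`, 7.28 in a physicochemical assay for lipophilicity; a higher number here means a more lipophilic compound, a lower number a more polar compound
- compound 2, `CCCOC(=O)/C=C(C)/C=C/CC(C)CCCC(C)(C)OC`, 6.08 in this assay
- compound 3, `CCCCOC(=O)/C=C(C)/C=C/CC(C)CCCC(C)(C)OC`, 6.62 in this assay

Compound 1 stands highest of the three in this assay; compound 3 sits nearest to it and compound 2 furthest. The step to compound 4, `C=CCSC(=O)/C=C(C)/C=C/CC(C)CCCC(C)C`, is allylsulfanyl in place of propoxy on a carbonyl carbon. Neither measured step touches that carbonyl carbon: a number 1.20 log units lower from compound 1 to compound 2 (beyond the scatter) and a number 0.54 log units higher from compound 2 to compound 3 (beyond the scatter) both alter the saturated chain far from it, so they describe the range of the series rather than this exchange. With no closer guide, a modest rise is expected, a number 0.42 log units higher from compound 1 to compound 4 (beyond the scatter), and compound 4 is estimated at 7.7, within 7.2 to 8.2.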

Compound 4, partition coefficient: 7.97
Compound 4: middle estimate off by 0.27 log units, on the low side, within the range that was stated.
By their numbers in this assay, from the lowest: compound 2; then compound 3; then compound 1; then compound 4.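

This is the first change shown on the carbonyl carbon itself, and in this assay allylsulfanyl in place of propoxy gives a number 0.69 log units higher from compound 1 to compound 4 (beyond the scatter). So this position, not only the far end of the saturated chain, can move the number beyond the scatter. Nothing shown explains this rise.

As far as these compounds go, the exchange replaces oxygen with sulfur and also brings in a double bond, so the share of each remains open; propylsulfanyl or allyloxy on the same carbonyl carbon would separate them. From the compounds shown here alone, whether the step would be the same size on the methoxy-bearing chain of compound 2 also remains open.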